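This account rests on a few compounds, and the source may have more. Where it says the series, first, only, none or still open, it means among the compounds named here.

Measured compounds:
Compound 1, `Cc1ccc(NC(=O)C(Cl)Cl)cc1`, in a functional assay on KB cells (Homo sapiens) for antiproliferative activity, read by MTT assay, with a stated time of 72 h; a lower number here means a stronger inhibitor, a higher number a weaker inhibitor: "not determined" (no result reported).
Compound 2, `O=C(Nc1ccc(Cl)cc1)C(Cl)Cl`, 60800 nM.
Compound 3, `O=C(Nc1ccc(Br)cc1)C(Cl)Cl`, 21700 nM.

Among the measured compounds shown here, compound 3 holds the lowest number of the two reported in this assay, and the only step that separates it from compound 2 is a 2.8-fold lower number from compound 2 to compound 3 (0.45 log units; beyond the scatter), a modest step that lies beyond the scatter. Compound 1 adds no number to this picture.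

Compound 4, `O=C(Nc1ccc(SC(F)(F)F)cc1)C(Cl)Cl`, differs from compound 3 in one place: (trifluoromethyl)sulfanyl in place of bromo on an aromatic carbon. For the measured compounds named here, the one measured step that bears on this change is a 2.8-fold lower number from compound 2 to compound 3 (0.45 log units; beyond the scatter), where one halogen replaced another on the same aromatic carbon and the number fell modestly. That step is only a loose guide here, since the entering group is not a halogen. In this assay the expected step is a 2.2-fold lower number from compound 3 to compound 4 (0.34 log units; beyond the scatter), downward and of roughly the size seen before. A step within the scatter cannot be excluded. Compound 4 is therefore estimated at 10000 nM, with a range from 3000 nM to 35000 nM.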

Compound 4, half-maximal inhibitory concentration: 2080 nM
For compound 4 the middle estimate is 4.8-fold (0.68 log units) above the measured one, outside the stated range (below it).
By their numbers in this assay, from the lowest: compound 4; then compound 3; then compound 2.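

In this assay the change from bromo to (trifluoromethyl)sulfanyl on this aromatic carbon gives a 10-fold lower number from compound 3 to compound 4 (1.02 log units; beyond the scatter) and is large, whereas the exchange of one halogen for another had moved the number only modestly. Measured against the chloro compound, the same group gives a 29-fold lower number from compound 2 to compound 4 (1.47 log units; beyond the scatter) and this too is large, so this carbon of the ring accepts a group that is no halogen and has more heavy atoms, and the number still falls. No measured property of these groups is at hand to account for the size of these steps.

As far as these compounds go, whether the sulfur, the fluorines or the group as a whole carries the fall remains open. Also open, from the compounds shown here alone, is how an amine, a carboxylic acid or a longer chain would stand on this same carbon.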